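Antiproliferative series: aryloxypropyl ethers on a shared core

The source may report more compounds than this note shows. Statements on the series, on what has been measured and on what is new or still open speak of the compounds shown alone.

Measured so far:
compound 1, `COc1ccc(OCCCON2C(N)=NC(N)=NC23CCOCC3)cc1`: 1500 nM
compound 2, `NC1=NC2(CCOCC2)N(OCCCOc2cc(Cl)c(Cl)cc2Cl)C(N)=N1`: 2750 nM
compound 3, `NC1=NC2(CCOCC2)N(OCCCOc2cccc(Cl)c2)C(N)=N1`: 120 nM

In a functional assay on HCT-116 cells (Homo sapiens) for antiproliferative activity, read by MTT assay, with a stated time of 72 h (on this read-out higher numbers stand for weaker inhibition and lower numbers for stronger inhibition), compound 1 gives 1500 nM, the second highest of three numbers; its nearest neighbour is compound 2, a 1.8-fold higher number from compound 1 to compound 2 (0.26 log units; within the scatter), and its furthest is compound 3, a 13-fold lower number from compound 1 to compound 3 (1.10 log units; beyond the scatter). Compound 4, `NC1=NC2(CCOCC2)N(OCCCOc2ccc(Br)cc2)C(N)=N1`, differs from compound 1 by bromo in place of methoxy on an aromatic carbon. Going by the values given here, no measured step swaps methoxy for a halogen at this place. Among the compounds with values here, the only guidance is that changes on the oxygen on a saturated carbon move the number widely: a 13-fold lower number from compound 1 to compound 3 (1.10 log units; beyond the scatter) and a 23-fold lower number from compound 2 to compound 3 (1.36 log units; beyond the scatter) are large, while a 1.8-fold higher number from compound 1 to compound 2 (0.26 log units; within the scatter) is not. A downward step is expected for compound 4, a 2.5-fold lower number from compound 1 to compound 4 (0.40 log units; beyond the scatter), with wide uncertainty. Compound 4 is therefore estimated at 600 nM, in the range 150 nM to 2500 nM.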

Compound 4, half-maximal inhibitory concentration: 320 nM
The estimate for compound 4 lay 1.9-fold (0.27 log units) above the measured number, within the range that was stated.
By their numbers in this assay, from the lowest: compound 3; then compound 4; then compounds 1 and 2 (each within the scatter of the next).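

In this assay, going by these compounds alone, the change of methoxy to bromo gives the first direct reading of a halogen at this place, on an aromatic carbon para to a large group (a 4.7-fold lower number from compound 1 to compound 4 (0.67 log units; beyond the scatter)). The 4-bromophenyl group falls short of 3-chlorophenyl (a 2.7-fold higher number from compound 3 to compound 4 (0.43 log units; beyond the scatter)) but lies well clear of 2,4,5-trichlorophenyl (an 8.6-fold lower number from compound 2 to compound 4 (0.93 log units; beyond the scatter)), so the presence of halogen on the ring does not alone set the number. Nothing available explains these steps. On these data alone, whether fluoro or iodo at this place follows bromo remains open. So does the outcome with an amine or a carboxylic acid there.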